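From tert-Butyl to Hydroxy: An Expected Drop in Lipophilicity

The compounds below may be only part of what the source reports. "The series", "measured", "known", "first", "only" and "open" are said of these compounds alone.

Compound 1 `NC(=O)c1c(COc2ccccc2/C=N/NC(=O)c2ccncc2)no[n+]1[O-]`: 1.3
Compound 2 `CC(C)(C)c1ccc(C(=O)N/N=C/c2ccc3no[n+]([O-])c3c2)cc1`: 3.8
Compound 3 `NC(=O)c1c(COc2cccc(/C=N/NC(=O)c3ccncc3)c2)no[n+]1[O-]`: 1.3

In a physicochemical assay for lipophilicity, read by HPLC, measured as octanol-water partition (on this read-out higher numbers stand for higher lipophilicity and lower numbers for lower lipophilicity), compound 2 gives 3.8, the highest of the three numbers; compound 1 and compound 3 both sit lower by gaps beyond the usual scatter. Compound 4 `O=C(N/N=C/c1ccc2no[n+]([O-])c2c1)c1ccc(O)cc1` has not yet been measured. It differs from compound 2 in one place: hydroxy in place of tert-butyl on an aromatic carbon. For the measured compounds named here, no measured pair shows a change of this kind, so there is no measured step to lean on. Still, with tert-butyl leaving and hydroxy entering, a decrease in this assay well beyond the scatter is expected, the expected step being a number 2.30 log units lower from compound 2 to compound 4 (beyond the scatter). Compound 4 is therefore estimated at 1.5, most likely between 0.9 and 2.1.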

Compound 4, partition coefficient: 1.2
The estimate for compound 4 lay 0.30 log units above the measured number; the range from low to high includes it.
By their numbers in this assay, from the lowest: compounds 4, 1 and 3 (each within the scatter of the next); then compound 2.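

In this assay, for the compounds shown here, the swap of tert-butyl for hydroxy on this aromatic carbon gives a number 2.60 log units lower from compound 2 to compound 4 (beyond the scatter) and is the first one-place change available here. It shows that a single group at this position, para to a large group, can move the read-out by a large amount while the rest of the molecule stays the same. No available evidence explains the size of this step.

On these data alone, whether an amine, a carboxylic acid or a methoxy group on this carbon would land nearer compound 2 or compound 4 remains open. So does whether the same swap would give a similar step on a different core.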